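The source may hold more compounds than are shown below. What is called first, only, known or untested is meant among the compounds shown, and "the series" means these compounds.

Measured compounds:

Compound 1, `Cn1c(SCc2ccccc2)nnc1-c1cc([N+](=O)[O-])cc([N+](=O)[O-])c1`: in an ADME assay on A-431 cells (Homo sapiens) for cytotoxicity, with a stated time of 48 h (a lower number here means a stronger inhibitor, a higher number a weaker inhibitor), compound 1 gives > 30000 nM, a limit of the assay rather than a number.
Compound 2, `CCCCCCn1c(SCc2ccccc2)nnc1-c1cc([N+](=O)[O-])cc([N+](=O)[O-])c1`: in this assay compound 2 gives > 30000 nM, again a limit of the assay.
Compound 3, `COc1ccc(CSc2nnc(-c3cc([N+](=O)[O-])cc([N+](=O)[O-])c3)n2C)cc1`: in this assay compound 3 gives > 30000 nM, also a limit of the assay.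

Compound 3 thus stands at the limit, and the two other measured values stand at the same limit; the limit of > 30000 nM in this assay, at which 3 of the 3 values shown sit, sums this up. The steps from compound 1 to compound 2, a step that the two limits leave unreadable from compound 1 to compound 2, and from compound 1 to compound 3, a step that the two limits leave unreadable from compound 1 to compound 3, cannot be sized, since both ends are limits.

Compound 4, `Cn1c(SCc2ccc(Br)cc2)nnc1-c1cc([N+](=O)[O-])cc([N+](=O)[O-])c1`, is not yet measured. It differs from compound 3 by bromo in place of methoxy on an aromatic carbon. Going by the values given here, no measured step reads on a change of this kind, and the one step that touches the same aromatic carbon, the one from compound 1 to compound 3, is unreadable. Compound 4 is therefore expected to remain at the limit in this assay, with a step that the limit leaves unreadable from compound 3 to compound 4 from compound 3 to compound 4 expected to be no more than the scatter. For compound 4 the estimated value in this assay is 45000 nM, with a range from 15000 nM to 150000 nM.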

Compound 4, half-maximal inhibitory concentration: > 30000 nM
Compound 4: only a limit was reported; the forecaster's own chance of this, stated with the estimate: 85%; the middle value is on the limit's open side.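

In this assay compound 4 gives > 30000 nM, which is a limit of the assay. Going by these compounds alone, no step to compound 4 from compound 1 or compound 3 can be read. The compounds shown leave open whether any of these changes moves the read-out at all: the limit of > 30000 nM in this assay, at which 4 of the 4 values shown sit.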